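A few compounds are considered here, and "the series" means these few. Any claim that something is new, unique, unknown or untested is made for them only; others in the source may bear on it.

Compound 3 `CC(CN1N=C(c2ccccc2)CCC1=O)C(=N)S` stands second highest of the three numbers measured in a functional assay on the whole organism (stomach) for inhibition, with Rattus norvegicus as the target, at a dose of 100 mg/kg by the intraduodenal route (a higher number here means more inhibition at the dose given (going by the name of the read-out), a lower number less inhibition), where compound 3 gives 28.2%; compound 2 `CC1=NN(CC(C)C(=N)S)C(=O)CC1` gives 15.6% and compound 1 `N=C(S)CCCCCCN1N=C(c2ccccc2)CCC1=O` gives 68.3%. Going by the values given here, the only measured step, a number 12.6 percentage points higher from compound 2 to compound 3 (beyond the scatter), concerns a different part of the structure and does not bear on the change to compound 4 `N=C(S)CCCCN1N=C(c2ccccc2)CCC1=O`, which carries a group of 6 heavy atoms (4 carbon, 1 nitrogen, 1 sulfur; no ring) in place of a group of 5 heavy atoms (3 carbon, 1 nitrogen, 1 sulfur; no ring), on a saturated chain carbon bound to an amide-type nitrogen in a ring. Among the compounds with values here, no step between measured compounds bears on this change; what the values of compound 1 and compound 3 show is that the longer chain goes with the higher number. Compound 4 is therefore expected to rise by a number 19.8 percentage points higher from compound 3 to compound 4 (beyond the scatter) in this assay. Compound 4 is estimated at 48%, with a range from 30% to 66%.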

Compound 4, a percentage reported as inhibition, in the whole organism at one dose (the size of the read-out at that dose, not a potency): 50.2%
Beside the measured number, compound 4's estimate is 2.2 percentage points below it; the measured number falls inside the stated range.
By their numbers in this assay, from the lowest: compound 2; then compound 3; then compound 4; then compound 1.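

In this assay the group on the saturated chain carbon bound to an amide-type nitrogen in a ring now has two readable steps: a number 22 percentage points higher from compound 3 to compound 4 (beyond the scatter) and a number 18.1 percentage points lower from compound 1 to compound 4 (beyond the scatter). Across compound 3, compound 4 and compound 1 the number therefore rises with the size of this group, and none of the three goes against that order. No measurement available here explains the rise. As far as these compounds go, whether a still longer chain would raise the number further remains open. So does the effect of an amine or a carboxylic acid in place of the chain's end group.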